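The source may hold more compounds than are shown below. What is called first, only, known or untested is meant among the compounds shown, and "the series" means these compounds.

Measured so far:
compound 1 `O=C1Nc2ccccc2/C1=C/c1ccc(-c2cn(-c3cccc(F)c3)nn2)cc1`: > 20000 nM (a limit)
compound 2 `O=C1Nc2ccccc2/C1=C/c1ccc(-c2cn(-c3ccccc3Cl)nn2)cc1`: > 20000 nM (a limit)
compound 3 `O=C1Nc2ccccc2/C1=C/c1ccc(-c2cn(-c3cccc(Cl)c3)nn2)cc1`: > 20000 nM (a limit)

In an ADME assay on HUVEC cells (Homo sapiens) for inhibition, read by CCK-8 assay, with a stated time of 24 h, in the presence of a further agent that is not named here (a lower number here means a stronger inhibitor, a higher number a weaker inhibitor), compound 1 gives > 20000 nM, which is a limit and not a number. Among the compounds with values here, the series so far offers a single reading: the limit of > 20000 nM in this assay, at which 3 of the 3 values shown sit.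

Compound 4 `N#Cc1cccc(-n2cc(-c3ccc(/C=C4\C(=O)Nc5ccccc54)cc3)nn2)c1` departs from compound 1 by one change: cyano in place of fluoro on an aromatic carbon. In words, this is cyano in place of fluoro on an aromatic carbon, or 3-fluorophenyl to 3-cyanophenyl.

The closest measured change is a step that the two limits leave unreadable from compound 1 to compound 3, made at the same place. Two further steps bear on it less directly: a step that the two limits leave unreadable from compound 1 to compound 2 and a step that the two limits leave unreadable from compound 2 to compound 3. None of the three has a readable size, so they set no direction and no magnitude for the new change, and cyano itself has not yet been measured in this series. The working expectation is therefore no clear departure from the limit, and the expected step is a number no higher from compound 1 to compound 4 (the limit leaves the size open). For compound 4 the estimated value is 20000 nM, with an expected range from 7000 nM to 40000 nM.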

Compound 4, half-maximal inhibitory concentration: > 20000 nM
Compound 4 ended at the assay's limit (the forecaster's own chance of this, stated with the estimate: 70%); the middle value sits exactly at the limit.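

In this assay compound 4 gives > 20000 nM, a limit and not a number, so its steps with compound 1, compound 2 and compound 3 cannot be read. The compounds shown leave open whether any change to the shared core gives a readable value in this assay.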